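A Thiophene Swap in a Flat Series

This account rests on a few compounds, and the source may have more. Where it says the series, first, only, none or still open, it means among the compounds named here.

Compound 1 (`O=C(CCCCCCC(=O)Nc1nnc(-c2ccco2)s1)NO`): 880 nM
Compound 2 (`Cc1ccc(-c2nnc(NC(=O)CCCCCCC(=O)NO)s2)o1`): 880 nM
Compound 3 (`O=C(CCCCCCC(=O)Nc1nnc(-c2ccc(Br)o2)s1)NO`): 880 nM

In a functional assay on ASPC1 cells (Homo sapiens) for inhibition, read by MTT assay (a higher number here means a weaker inhibitor, a lower number a stronger inhibitor), compound 1, compound 2 and compound 3 read alike, and compound 3 at 880 nM stands level with the other two.

Compound 4 (`Cc1ccc(-c2nnc(NC(=O)CCCCCCC(=O)NO)s2)s1`) differs from compound 3 in one place (5-methylthiophen-2-yl in place of 5-bromofuran-2-yl on an aromatic carbon): 5-methylthiophen-2-yl in place of 5-bromofuran-2-yl on an aromatic carbon of a five-membered aromatic ring with 2 nitrogen and 1 sulfur.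

For the measured compounds named here, three measured steps bear on this change. Methyl in place of hydrogen (no change at the digits printed from compound 1 to compound 2 (within the scatter)), bromo in place of hydrogen (no change at the digits printed from compound 1 to compound 3 (within the scatter)) and bromo in place of methyl (no change at the digits printed from compound 2 to compound 3 (within the scatter)) all leave the reading where it was. Going by the values given here, none of the measured compounds carries a thiophene ring, so that part of the change is untested. With only these flat steps to go on, no step beyond the scatter is expected in this assay in either direction. The expected step (no change at the digits printed from compound 3 to compound 4 (within the scatter)) is only an estimate, and its range is kept wide for the untested ring. Compound 4 is estimated at 880 nM with an expected range from 400 nM to 1900 nM as the likely outcome.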

Compound 4, half-maximal inhibitory concentration: 880 nM
Beside the measured number, compound 4's estimate shows no gap at the digits printed, and the stated range covers the measured number.
By their numbers in this assay, from the lowest: compounds 1, 2, 3 and 4 (each within the scatter of the next).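

The cleanest test of the ring is the swap of 5-methylfuran-2-yl for 5-methylthiophen-2-yl, where the methyl stays and only the ring's hetero atom differs, and in this assay it gives no change at the digits printed from compound 2 to compound 4 (within the scatter). The two wider swaps, which alter the ring and its substituent together, tell the same story: no change at the digits printed from compound 3 to compound 4 (within the scatter) and no change at the digits printed from compound 1 to compound 4 (within the scatter). For the compounds shown here, this adds what the earlier compounds could not show: on this aromatic carbon, next to the ring nitrogen and the ring sulfur, the thiophene ring reads the same as the furan ring, so the flat picture now covers a change of ring as well as a change of substituent.

Nothing measured alongside these readings explains why they stay level, so the flat result remains a plain observation. From the compounds shown here alone, all four compounds share one reading, so it remains open whether any group at this position can shift it, for example an amine or a carboxylic acid on the ring, or a phenyl ring in place of the thiophene.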